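The compounds below may be only part of what the source reports. "The series", "measured", "known", "first", "only" and "open" are said of these compounds alone.

Measured so far:
- Compound 1, `Clc1ccc(C2Cc3nccn3C2)cc1`: 3460 nM
- Compound 2, `NC(=O)c1ccccc1C1Cc2nccn2C1`: 371 nM
- Compound 3, `c1ccc(C2CCc3nccn3C2)cc1`: 721 nM

These three numbers come from a functional assay on CHO cells for agonist activity at Alpha-1A adrenergic receptor (Homo sapiens), read by FLIPR and calcium flux; on this read-out lower numbers stand for an effect already at smaller amounts and higher numbers for an effect only at larger amounts of compound. Compound 2 gives the lowest of the three numbers. The gap between compound 2 and compound 3 is within the scatter of repeated measurements, so no order can be read between these two. Compound 1 lies well beyond the scatter and is the furthest from compound 2.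

Compound 4, `COc1ccccc1C1Cc2nccn2C1`, is not yet measured. It differs from compound 2 in one place: methoxy in place of carbamoyl on an aromatic carbon. For the measured compounds named here, no measured pair shows this exchange, so nothing tells its size or direction. The three measured values all sit in a fairly narrow band apart from compound 1, and the expected step from compound 2 to compound 4 is taken as small, most likely toward a higher number, but the range must stay wide.

Compound 4 is expected to give 900 nM, with a range from 250 nM to 3500 nM. That estimate corresponds to an expected step of a 2.4-fold higher number from compound 2 to compound 4 (0.38 log units; beyond the scatter).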

Compound 4, half-maximal effective concentration: 22 nM
Compound 4: middle estimate off by 41-fold (1.61 log units), on the high side, outside the stated range (below it).
By their numbers in this assay, from the lowest: compound 4; then compounds 2 and 3 (each within the scatter of the next); then compound 1.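

In this assay, methoxy in place of carbamoyl on an aromatic carbon, ortho to a group of 8 heavy atoms, gives a 17-fold lower number from compound 2 to compound 4 (1.23 log units; beyond the scatter) and shows that this single place on the ring can shift the number by a large amount. The exchange removes the hydrogen-bond donor and one heavy atom and keeps one hydrogen-bond acceptor, but these counts alone do not show which difference matters. No measurement here gives a reason for the size of this step.

Going by these compounds, it remains open how an ethoxy group, a hydroxyl group or an amine on the same carbon would compare with methoxy. On these data alone, it is also open whether methoxy would give a similar step at another carbon of this ring or on the core of compound 3.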